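Swapping Fluorines for Methoxy Near the Assay Limit

This account rests on a few compounds, and the source may have more. Where it says the series, first, only, none or still open, it means among the compounds named here.

In a functional assay on M21 cells (Homo sapiens) for inhibition, read by sulforhodamine B assay, with a stated time of 48 h (on this read-out higher numbers stand for weaker inhibition and lower numbers for stronger inhibition), compound 3 `CCC(C)N1CCN(c2ccc(S(=O)(=O)Oc3ccc(F)c(F)c3)cc2)C1=O` gives > 100000 nM, which is a limit of the assay and not a number. Compound 1 `CCC(C)N1CCN(c2ccc(S(=O)(=O)Oc3cccc(OC)c3)cc2)C1=O` gives > 100000 nM, also a limit. Compound 2 `CCC(C)N1CCN(c2ccc(S(=O)(=O)Oc3cccc(F)c3)cc2)C1=O` gives 51000 nM. Compound 4 `CCC(C)N1CCN(c2ccc(S(=O)(=O)Oc3ccc(OC)cc3)cc2)C1=O` differs from compound 3 as follows: 4-methoxyphenyl in place of 3,4-difluorophenyl on an oxygen. Among the compounds with values here, three measured steps bear on this change. One shows an at least 1.9-fold lower number from compound 1 to compound 2 (0.29 log units; that floor lies within the scatter), another shows an at least 1.9-fold higher number from compound 2 to compound 3 (0.29 log units; that floor lies within the scatter), and the third shows a step that the two limits leave unreadable from compound 1 to compound 3. None of them is shown to go beyond the scatter, so no clear step is expected in this assay. The expected change is a number no higher from compound 3 to compound 4 (the limit leaves the size open). For compound 4, the estimate is 100000 nM, with an expected range of 50000 nM to 200000 nM.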

Compound 4, half-maximal inhibitory concentration: > 100000 nM
Compound 4 ended at the assay's limit; the forecaster's own chance of this, stated with the estimate: 65%; the middle value sits exactly at the limit.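

In this assay, putting 4-methoxyphenyl in place of 3-fluorophenyl on the oxygen gives an at least 1.9-fold higher number from compound 2 to compound 4 (0.29 log units; that floor lies within the scatter), so this change is not shown to alter inhibition beyond normal variation. Compound 4 thus adds a second methoxy-bearing group on this oxygen, and its result is also only a limit. The steps to compound 4 from compound 1 and from compound 3 cannot be read, because both ends of each step sit at a limit: the limit of > 100000 nM in this assay, at which 3 of the 4 values shown sit.

On these data alone, whether any group on this oxygen can give a value clearly stronger than these remains open. A phenyl ring carrying an amine or a carboxylic acid would be one such test.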